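The source may report more compounds than this note shows. Statements on the series, on what has been measured and on what is new or still open speak of the compounds shown alone.

The shared core of this small series is seen in compound 1 `CC(C)C[C@H](N)c1cc(C(F)(F)F)ccc1N1CCN(C(=O)C(C)Cc2ccc(Cl)cc2)CC1`, which carries a 1-(4-chlorobenzyl)ethyl group on the carbonyl carbon. In an assay on HEK293 cells for displacement of a labelled ligand from Melanocortin receptor 4 (Homo sapiens) (a higher number here means a weaker inhibitor, a lower number a stronger inhibitor), compound 1 gives 47 nM. Compound 2 `CC(C)C[C@H](N)c1cc(C(F)(F)F)ccc1N1CCN(C(=O)CCC(=O)N(C)C)CC1` carries a 2-(dimethylcarbamoyl)ethyl group at that carbonyl carbon instead. In this assay compound 2 gives > 10000 nM, which is a limit of the assay and not a number. Compound 2 therefore stands at the limit of > 10000 nM in this assay, at which 1 of the 2 values shown sits, and the step of an at least 210-fold higher number from compound 1 to compound 2 (2.32 log units; beyond the scatter) marks it as the weaker of the two measured compounds by a wide margin.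

Compound 3 `CCOc1cccc(CC(C)C(=O)N2CCN(c3ccc(C(F)(F)F)cc3[C@@H](N)CC(C)C)CC2)c1` reverses that change: 1-(3-ethoxybenzyl)ethyl in place of 2-(dimethylcarbamoyl)ethyl on a carbonyl carbon. Within the data shown here, the entering 1-(3-ethoxybenzyl)ethyl group resembles the 1-(4-chlorobenzyl)ethyl group of compound 1 much more than the group it replaces, so the one measured step that bears on this change is an at least 210-fold higher number from compound 1 to compound 2 (2.32 log units; beyond the scatter), which was large. Going back in the other direction is expected to undo most of that loss, with an estimated drop in this assay of an at least 120-fold lower number from compound 2 to compound 3 (2.09 log units; beyond the scatter). Compound 3 is therefore estimated at 80 nM in this assay, with a range from 15 nM to 500 nM.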

Compound 3, inhibition constant: 2200 nM
Beside the measured number, compound 3's estimate is 28-fold (1.44 log units) below it, and the stated range ends below it.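

Restoring an aromatic ring to the group on the carbonyl carbon recovers only part of the lost binding in this assay, with an at least 4.5-fold lower number from compound 2 to compound 3 (0.65 log units; beyond the scatter), while there is still a 47-fold higher number from compound 1 to compound 3 (1.67 log units; beyond the scatter). A benzyl-type group at this position is therefore not enough on its own for the level of compound 1, and what the aromatic ring carries also matters: exchanging 4-chlorophenyl for 3-ethoxyphenyl on the same chain gives a large change, even though the rest of the molecule stays the same. The value for compound 2 is a limit of the assay and not a number, so only a minimum can be given for the gain from that compound: the limit of > 10000 nM in this assay, at which 1 of the 3 values shown sits.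

The 4-chlorophenyl and 3-ethoxyphenyl groups differ both in the substituent and in where it sits on the ring, so the compounds shown cannot tell which of these two differences accounts for the large step. A 3-chlorophenyl or 4-ethoxyphenyl group on the same chain would separate the two effects, and an unsubstituted phenyl group would show what each substituent contributes.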